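A few compounds are considered here, and "the series" means these few. Any claim that something is new, unique, unknown or untested is made for them only; others in the source may bear on it.

Compound 1 `Cc1ccc(-n2nc(C(=O)Nc3ccc(Oc4ncnc5ccsc45)cc3)c(C)cc2=O)cc1` and compound 3 `Cc1ccc(-n2nc(C(=O)Nc3ccc(Oc4ncnc5sccc45)cc3)c(C)cc2=O)cc1` are built from the same atoms joined differently, and the difference between their cores is a group of 9 heavy atoms (6 carbon, 2 nitrogen, 1 sulfur; one five-membered aromatic ring with 1 hetero atom, one six-membered aromatic ring with 2 hetero atoms) in place of a group of 9 heavy atoms (6 carbon, 2 nitrogen, 1 sulfur; one five-membered aromatic ring with 1 hetero atom, one six-membered aromatic ring with 2 hetero atoms), on an oxygen on an aromatic ring. In a functional assay on A549 cells (Homo sapiens) for cytotoxicity, read by MTT assay, with a stated time of 72 h (on this read-out lower numbers stand for stronger inhibition and higher numbers for weaker inhibition), compound 1 gives 11500 nM. Among the compounds with values here, compound 3 reaches only a limit of this assay, > 40000 nM, and among the values measured so far this is the limit of > 40000 nM in this assay, at which 1 of the 3 values shown sits. The step of an at least 3.4-fold higher number from compound 1 to compound 3 (0.54 log units; beyond the scatter) is accordingly bounded on one side only.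

Compound 2 `Cc1cc(=O)n(-c2ccc(F)cc2)nc1C(=O)Nc1ccc(Oc2ncnc3ccsc23)cc1` carries on the core of compound 1 the change (fluoro in place of methyl on an aromatic carbon). In this assay compound 2 gives 2360 nM, which means a 4.9-fold lower number from compound 1 to compound 2 (0.69 log units; beyond the scatter).

Compound 4 `Cc1cc(=O)n(-c2ccc(F)cc2)nc1C(=O)Nc1ccc(Oc2ncnc3sccc23)cc1` has not yet been measured. It stands to compound 3 as compound 2 stands to compound 1, carrying the same change (fluoro in place of methyl on an aromatic carbon), and the two descriptions of the place match word for word. Whether the change earns a comparable step on the core of compound 3 cannot be read from one example, and the starting point for compound 4 is itself only a limit. The step from compound 3 to compound 4 is estimated as an at least 2.0-fold lower number from compound 3 to compound 4 (0.30 log units; that floor lies within the scatter), an expectation that rests on the earlier pair because the same change gave a 4.9-fold lower number from compound 1 to compound 2 (0.69 log units; beyond the scatter). In this assay compound 4 is therefore expected to show about 20000 nM, with a likely range from 6000 nM to 60000 nM.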

Compound 4, half-maximal inhibitory concentration: 7050 nM
Beside the measured number, compound 4's estimate is 2.8-fold (0.45 log units) above it, and the stated range covers the measured number.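

In this assay, the change from 4-methylphenyl to 4-fluorophenyl also gives a lower number on the second core, an at least 5.6-fold lower number from compound 3 to compound 4 (0.75 log units; beyond the scatter), so it points the same way on both cores shown: the same change on two cores in this assay, a 4.9-fold lower number (0.69 log units; beyond the scatter) from compound 1 to compound 2 and an at least 5.6-fold lower number (0.75 log units; beyond the scatter) from compound 3 to compound 4; the limit leaves it open whether they differ. The change of core, read with the 4-fluorophenyl group in place, gives a 3.0-fold higher number from compound 2 to compound 4 (0.48 log units; beyond the scatter), and this points the same way as the core change read with the 4-methylphenyl group: the same change on two cores in this assay, an at least 3.4-fold higher number (0.54 log units; beyond the scatter) from compound 1 to compound 3 and a 3.0-fold higher number (0.48 log units; beyond the scatter) from compound 2 to compound 4; the limit leaves it open whether they differ. Compound 3 stands at a limit of the assay, so the pairs that include it show direction but not an exact step size, and two cores cannot show that the change would carry over to any other core: the limit of > 40000 nM in this assay, at which 1 of the 4 values shown sits.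

The compounds shown leave open what chloro, methoxy or an amine would do in place of the methyl on that aromatic carbon, on either core. They also leave open whether the order of the two cores would hold with such groups, and whether the same steps would appear on a third core.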